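The source may report more compounds than this note shows. Statements on the series, on what has been measured and on what is new or still open speak of the compounds shown alone.

Among the measured compounds shown here, compound 1 `CN1CCC[C@H]1[C@H]1COc2ccc(N)cc2O1` gives 180 nM in an assay on membranes from HEK293 cells for displacement of a labelled ligand from Neuronal acetylcholine receptor; alpha3/beta4 (Homo sapiens), with a stated time of 5 min (on this read-out lower numbers stand for stronger inhibition and higher numbers for weaker inhibition), the lowest of the three numbers measured so far. Compound 2 `CN1CCC[C@H]1[C@H]1COc2cc(N)ccc2O1`, which carries the amino group on a different carbon of the shared core, gives 8600 nM in this assay, and compound 3 `CN1CCC[C@H]1[C@H]1COc2cc([N+](=O)[O-])ccc2O1`, with a nitro group at that same position, gives 4800 nM. For the measured compounds named here, the one change that can be followed step by step, a 1.8-fold lower number from compound 2 to compound 3 (0.25 log units; within the scatter), concerns the second position rather than the one altered here. Compound 4 `CC(=O)Nc1ccc2c(c1)O[C@@H]([C@@H]1CCCN1C)CO2` differs from compound 1 by acetyl in place of hydrogen on a nitrogen on an aromatic ring. Going by the values given here, no measured pair shows this exact change, so the expectation rests on compound 1 alone, because its number 180 nM is the starting point, while the swap between compounds 2 and 3 offers no guide for acetylation. A modest weakening is expected, so that a 3.3-fold higher number from compound 1 to compound 4 (0.52 log units; beyond the scatter), though a result within the scatter cannot be excluded. Compound 4 is therefore estimated at 600 nM, within a range from 150 nM to 3000 nM.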

Compound 4, inhibition constant: 8700 nM
Compound 4: the middle estimate sits 15-fold (1.16 log units) below what was measured, outside the stated range (above it).
By their numbers in this assay, from the lowest: compound 1; then compounds 3, 2 and 4 (each within the scatter of the next).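

In this assay, going from amino to acetamido on this nitrogen gives a 48-fold higher number from compound 1 to compound 4 (1.68 log units; beyond the scatter), so adding acetyl here has a large effect on the number. Among the compounds shown here, the only earlier step, a 1.8-fold lower number from compound 2 to compound 3 (0.25 log units; within the scatter), concerned a group on a different carbon of the shared core and stayed within the scatter, so this is the first clear sign that the assay responds to a change at this position. Nothing at hand explains why acetyl has an effect of this size.

From the compounds shown here alone, it remains open whether a methyl group or a methanesulfonyl group on this nitrogen would act as acetyl does, and whether a longer acyl chain such as propionyl would shift the number further. Going by these compounds, the effect of acetyl on the amino group of compound 2 also remains unknown.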